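The source may hold more compounds than are shown below. What is called first, only, known or untested is meant among the compounds shown, and "the series" means these compounds.

In a functional assay on HOP-92 cells (Homo sapiens) for antiproliferative activity (a higher number here means that more compound is tolerated, a lower number that less compound is tolerated), compound 1 `CC(=O)Nc1ccc(S(=O)(=O)NNC(=O)c2cccnc2Nc2ccc(Cl)cc2)cc1` gives only a limit, > 100000 nM, so its true level is not known beyond that (the limit of > 100000 nM in this assay, at which 1 of the 2 values shown sits). A second compound in the set, compound 2 `O=C(NNS(=O)(=O)c1ccc(F)cc1)c1cccnc1Nc1ccc(Cl)cc1Cl`, gives an actual number in this assay, namely 85100 nM. Compound 3 `O=C(NNS(=O)(=O)c1ccc(Cl)cc1Cl)c1cccnc1Nc1ccc(Cl)cc1` has not been measured yet. It differs from compound 1 in one place: 2,4-dichlorophenyl in place of 4-acetamidophenyl on a sulfonyl sulfur. Among the measured compounds shown here, no measured pair in this set shows this exact change, so the size of the step can only be estimated, not read from data. The step is expected to run downward in this assay, toward less compound being tolerated, by about an at least 1.6-fold lower number from compound 1 to compound 3 (0.22 log units; that floor lies within the scatter). Compound 3 is therefore expected to give roughly 60000 nM in this assay, with a range from 20000 nM to 100000 nM, and a fair chance that only a limit is reported again.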

Compound 3, concentration lethal to 50% of the cells: > 100000 nM
Compound 3: only a limit was reported (the forecaster's own chance of this, stated with the estimate: 40%); middle value at least 1.6-fold (0.22 log units) from the limit.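

Compound 1 and compound 3 each give only a limit, so no step can be read between them: the limit of > 100000 nM in this assay, at which 2 of the 3 values shown sit. The compounds shown leave open where their true levels lie, and whether 2,4-dichlorophenyl in place of 4-acetamidophenyl on a sulfonyl sulfur changes them at all.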